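Arylsulfonyl variation on the aminothiazole cyclohexylamine series

The source may report more compounds than this note shows. Statements on the series, on what has been measured and on what is new or still open speak of the compounds shown alone.

Compound 1 `CCCN(CC[C@H]1CC[C@H](NS(=O)(=O)c2ccccc2)CC1)[C@H]1CCc2nc(N)sc2C1` gives 0.79 nM in an assay on brain for displacement of a labelled ligand from D(3) dopamine receptor (Rattus norvegicus); on this read-out lower numbers stand for stronger inhibition and higher numbers for weaker inhibition.
Compound 2 `CCCN(CC[C@H]1CC[C@H](NS(=O)(=O)c2ccc(-c3ccccc3)cc2)CC1)[C@H]1CCc2nc(N)sc2C1` gives 41 nM.
Compound 3 `CCCN(CC[C@H]1CC[C@H](NS(=O)(=O)c2ccccc2Cl)CC1)[C@H]1CCc2nc(N)sc2C1` gives 0.68 nM.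

Compound 3 shows the lowest of the three numbers. Compound 1 stands nearest: the step of a 1.2-fold lower number from compound 1 to compound 3 (0.07 log units; within the scatter) lies within the scatter, so the two cannot be ordered. Compound 2 stands furthest, as the step of a 60-fold lower number from compound 2 to compound 3 (1.78 log units; beyond the scatter) shows.

Compound 4 `CCCN(CC[C@H]1CC[C@H](NS(=O)(=O)c2ccc(C(C)(C)C)cc2)CC1)[C@H]1CCc2nc(N)sc2C1` differs from compound 3 in one place: 4-(tert-butyl)phenyl in place of 2-chlorophenyl on a sulfonyl sulfur. Among the compounds with values here, two measured steps bear on this. Putting a phenyl on an aromatic carbon of the sulfonyl substituent gave a 52-fold higher number from compound 1 to compound 2 (1.72 log units; beyond the scatter), a large loss. Read the other way, a 60-fold lower number from compound 2 to compound 3 (1.78 log units; beyond the scatter) returns that loss once the ring carries only a chloro. The 4-(tert-butyl)phenyl of compound 4 again carries a bulky group on the ring, though not a phenyl, so a clear step upward is expected for compound 4, smaller than the phenyl step, about a 12-fold higher number from compound 3 to compound 4 (1.07 log units; beyond the scatter). Compound 4 is estimated at 8 nM, within 2 nM to 40 nM.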

Compound 4, inhibition constant: 5 nM
Estimate against measurement, compound 4: 1.6-fold (0.20 log units) above, and the stated range covers the measured number.
By their numbers in this assay, from the lowest: compounds 3 and 1 (each within the scatter of the next); then compound 4; then compound 2.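

Replacing the aryl group on the sulfonyl sulfur gives an intermediate level: a 7.4-fold higher number from compound 3 to compound 4 (0.87 log units; beyond the scatter) and a 6.3-fold higher number from compound 1 to compound 4 (0.80 log units; beyond the scatter) are both modest steps, while an 8.2-fold lower number from compound 2 to compound 4 (0.91 log units; beyond the scatter) recovers only part of the loss seen with the 4-phenylphenyl group. The loss on substitution of the aryl ring is therefore not confined to an added phenyl, since tert-butyl also carries a cost. Across these four compounds, the number rises from hydrogen to tert-butyl to phenyl on the aromatic carbon, and compound 3 goes against any rule covering all added groups, as its chloro step stays within the scatter.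

Open, going by these compounds, is whether a methyl, methoxy, amine or carboxylic acid on the ring would stay close to compound 1 or follow compound 4. No measurement shown explains these steps.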